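Triazine core: a secondary amine replaces the allyl-cyclopropyl pair

The compounds below may be only part of what the source reports. "The series", "measured", "known", "first", "only" and "open" are said of these compounds alone.

Going by the values given here, in an assay on isolated protein for binding affinity to corticotropin-releasing factor receptor 1 (Homo sapiens) (on this read-out lower numbers stand for stronger inhibition and higher numbers for weaker inhibition), compound 1 `C=CCN(c1nc(C)nc(N(CC)c2ccc(C(C)C)cc2Br)n1)C1CC1` gives 5 nM, the lower of the two numbers so far; compound 2 `CCN(CC)c1cc(C)nc(N(CC)c2ccc(N(C)C)cc2C(F)(F)F)n1` gives 11 nM in this assay, a gap beyond the usual scatter. Compound 3 `CCC(CC)Nc1nc(C)nc(N(CC)c2ccc(C(C)C)cc2Br)n1` differs from compound 1 in one place: (pentan-3-yl)amino in place of allyl(cyclopropyl)amino on an aromatic carbon. The new group keeps the same attachment point and carries one hydrogen-bond donor where compound 1 had none. Among the compounds with values here, no measured pair shows this exact change, so only a modest step is expected, in either direction or none beyond the scatter, giving an expected step of a 1.6-fold higher number from compound 1 to compound 3 (0.20 log units; within the scatter). Compound 3 is estimated at 8 nM in this assay, within 2 nM to 30 nM.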

Compound 3, inhibition constant: 41 nM
Beside the measured number, compound 3's estimate is 5.1-fold (0.71 log units) below it; measured number above the stated range.
By their numbers in this assay, from the lowest: compound 1; then compound 2; then compound 3.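

In this assay, this position on the aromatic carbon proves sensitive to the choice of amine: replacing allyl(cyclopropyl)amino with (pentan-3-yl)amino gives an 8.2-fold higher number from compound 1 to compound 3 (0.91 log units; beyond the scatter) and the weaker result. Going by these compounds alone, the swap removes the three-membered ring and the double bond and adds a hydrogen-bond donor, all at once, so the single step cannot separate them. Nothing available here gives a cause for the step. Cyclopropylamino would keep the ring alongside a donor, while methyl(pentan-3-yl)amino would keep the branched chain without one. From the compounds shown here alone, how either would compare remains open.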